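The source may hold more compounds than are shown below. What is called first, only, known or untested is meant among the compounds shown, and "the series" means these compounds.

Working notes on the series. Compound 1 `COc1ccc(-n2c(S)nnc2Sc2nnc(-c3ccccc3)n2-c2ccccc2)cc1` has no result in a functional assay on MDA-MB-231 cells (Homo sapiens) for inhibition, read by MTT assay, with a stated time of 48 h; on this read-out lower numbers stand for stronger inhibition and higher numbers for weaker inhibition; in that assay compound 1 is recorded as "not determined" (no result reported) and therefore stands at no number there. For the measured compounds named here, compound 2 `Sc1nnc(CSc2nnc(-c3ccccc3)n2-c2ccccc2)n1-c1ccccc1` is the sole measured member; in this assay compound 2 gives 8570 nM. Compound 3 `Sc1nnc(Sc2nnc(-c3ccccc3)n2-c2ccccc2)n1-c1ccccc1` differs from compound 1 by hydrogen in place of methoxy on an aromatic carbon. Going by the values given here, no measured pair sizes such a change, so the expected step in this assay is taken as small, within the scatter and of no fixed direction. Among the compounds with values here, compound 3 is therefore expected to land near the single measured value of the series. Compound 3 is estimated at 8000 nM, with a range from 2500 nM to 25000 nM.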

Compound 3, half-maximal inhibitory concentration: 34600 nM
Compound 3: middle estimate off by 4.3-fold (0.64 log units), on the low side; measured number above the stated range.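

For the compounds shown here, no step from compound 1 to compound 3 can be read in this assay, as compound 1 has no number there. From the compounds shown here alone, the size and direction of the change from 4-methoxyphenyl to phenyl remain open. No supporting data bear on this result.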